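The compounds below may be only part of what the source reports. "The series", "measured", "known", "first", "only" and "open" are said of these compounds alone.

Within the data shown here, compound 2 `Cc1cc(O)cc(-c2nn(CC#N)cc2-c2ccnc(-c3ccc(Oc4ccccc4)cc3)c2)c1` stands highest of the two numbers so far in a functional assay on A498 cells (Homo sapiens) for cytotoxicity, read by sulforhodamine B assay, with a stated time of 48 h, tested at 0.01 uM; on this read-out lower numbers stand for a stronger effect and higher numbers for a weaker effect at the one concentration tested: compound 2 gives 78%, while compound 1 `COc1cc(C)cc(-c2nn(CC#N)cc2-c2ccc(-c3cccc(C(C)=O)c3)nc2)c1` gives 60%, a gap beyond the scatter. Compound 3 `Cc1cc(O)cc(-c2nn(CC#N)cc2-c2ccnc(-c3ccc(N(C)C)cc3)c2)c1` differs from compound 2 by dimethylamino in place of phenoxy on an aromatic carbon. Among the measured compounds shown here, no step between measured compounds shows what this exchange does, so only a modest shift is expected, possibly none beyond the scatter, in either direction. The step of a number 8 percentage points lower from compound 2 to compound 3 (within the scatter) is the estimated change. Compound 3 is expected to give 70% in this assay, with a likely range from 45% to 95%.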

Compound 3, a percentage reported as activity, at one concentration (the size of the read-out at that concentration, not a potency): 80%
Compound 3: the middle estimate sits 10 percentage points below what was measured, and the stated range covers the measured number.
By their numbers in this assay, from the lowest: compound 1; then compounds 2 and 3 (each within the scatter of the next).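

Replacing phenoxy with dimethylamino, para to a large group, gives a number 2 percentage points higher from compound 2 to compound 3 (within the scatter) in this assay. At this position, then, the aromatic ring of phenoxy can give way to a group with no ring and fewer heavy atoms without a shift beyond the scatter, and the single hydrogen-bond acceptor is common to both groups. No available evidence explains this result. From the compounds shown here alone, it remains open whether a carboxylic acid or a primary amine at this position would separate from compound 2 and compound 3. A longer chain on the amine nitrogen is equally unresolved.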